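Lengthening the chain on the ring nitrogen

The source may hold more compounds than are shown below. What is called first, only, known or untested is meant among the compounds shown, and "the series" means these compounds.

Compound 2 `CCn1nc(Cc2ccc(Cl)cc2)c2ccccc2c1=O` carries an ethyl group on an aromatic nitrogen of its core. Within the data shown here, in a functional assay on aorta with Alpha-1D adrenergic receptor (Rattus norvegicus) as the target (a lower number here means that less compound is needed, a higher number that more compound is needed for the effect), compound 2 gives 1300 nM, the only actual number among the measured compounds. Compound 1 `CC(C)(C)n1nc(Cc2ccc(Cl)cc2)c2ccccc2c1=O`, with a tert-butyl group in the same place, reaches only a limit in this assay, > 100000 nM. That limit for compound 1 is the limit of > 100000 nM in this assay, at which 1 of the 2 values shown sits. Among the measured compounds shown here, the one measured step, an at least 76-fold lower number from compound 1 to compound 2 (1.88 log units; beyond the scatter), shows that the smaller ethyl group comes with a far lower number than tert-butyl. Compound 3 `CCCCn1nc(Cc2ccc(Cl)cc2)c2ccccc2c1=O` differs from compound 2 by ethyl in place of hydrogen on a saturated chain carbon, two bonds along the chain from an aromatic nitrogen, so the ethyl becomes a butyl. This change resembles the measured step in that it alters the size of the group on the nitrogen, but it runs the other way, growing the group rather than shrinking it. Given the size of the measured step, the step expected for compound 3 is estimated as a 3.1-fold higher number from compound 2 to compound 3 (0.49 log units; beyond the scatter), a rise in the number that is smaller than that measured step. Compound 3 is therefore estimated at 4000 nM, within a range from 1000 nM to 20000 nM.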

Compound 3, half-maximal effective concentration: > 100000 nM
Compound 3 gave a limit, no number (the forecaster's own chance of this, stated with the estimate: 10%); at least 25-fold (1.39 log units) between middle value and limit.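

Lengthening ethyl to butyl gives an at least 76-fold higher number from compound 2 to compound 3 (1.88 log units; beyond the scatter), so in this assay a straight chain on the aromatic nitrogen can also push the number far up, and the branched tert-butyl group of compound 1 is no longer the only group there that ends at a limit. Among these compounds, compound 2 is now the only one of the three compounds with an actual number, which makes its ethyl group the single readable point at this position. Compound 1 and compound 3 end at the same limit, so the step between them cannot be read and any difference between butyl and tert-butyl stays hidden: the limit of > 100000 nM in this assay, at which 2 of the 3 values shown sit.

The compounds shown leave open how the number changes with a propyl or a methyl group on the nitrogen, or with a plain hydrogen there, so it remains unclear whether ethyl is the best choice or simply one point on a slope. Also open, on these data alone, is whether a chain carrying an amine or a carboxylic acid would give a measurable number at this position.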